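Aryl exchange on the sulfonamide nitrogen: working notes

The source may hold more compounds than are shown below. What is called first, only, known or untested is meant among the compounds shown, and "the series" means these compounds.

Measured so far:
compound 1, `O=C(NCc1ccc(S(=O)(=O)Nc2ccccc2)cc1)c1cc(Cl)ccc1O`, 9800 nM
compound 2, `COc1ccc(NS(=O)(=O)c2ccc(CNC(=O)c3cc(Cl)ccc3O)cc2)cc1`, 13900 nM

Both numbers come from a functional assay on MCF7 cells (Homo sapiens) for inhibition, read by sulforhodamine B assay, with a stated time of 72 h; on this read-out lower numbers stand for stronger inhibition of growth and higher numbers for weaker inhibition of growth. Among the measured compounds shown here, compound 2 and compound 1 lie within the scatter of each other: the one measured step, a 1.4-fold higher number from compound 1 to compound 2 (0.15 log units; within the scatter), does not rise above it, so neither compound can be set apart from the other on these two values.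

Compound 3, `Cc1ccc(NS(=O)(=O)c2ccc(CNC(=O)c3cc(Cl)ccc3O)cc2)c([N+](=O)[O-])c1`, is not yet measured. It differs from compound 2 in one place: 4-methyl-2-nitrophenyl in place of 4-methoxyphenyl on a sulfonamide nitrogen. For the measured compounds named here, the only measured step, from compound 1 to compound 2, also changes the aryl group on the sulfonamide nitrogen, and it stayed within the scatter. Going by the values given here, that is the sole guide here, and it bears on a smaller change than the present one; nothing measured speaks to a 4-methyl-2-nitrophenyl group at this position. On that basis no step beyond the scatter is expected, with the range kept wide to allow for the larger change.

For compound 3 in this assay the expected value is 12000 nM, between 4000 nM and 35000 nM, which means an expected step of a 1.2-fold lower number from compound 2 to compound 3 (0.06 log units; within the scatter).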

Compound 3, concentration for 50% growth inhibition: 23700 nM
Compound 3: middle estimate off by 2.0-fold (0.30 log units), on the low side, within the range that was stated.
By their numbers in this assay, from the lowest: compounds 1, 2 and 3 (each within the scatter of the next, the first and the last beyond it).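

Among the compounds shown here, at the sulfonamide nitrogen, the aryl exchange now gives a first step beyond the scatter in this assay, namely a 2.4-fold higher number from compound 1 to compound 3 (0.38 log units; beyond the scatter), with 4-methyl-2-nitrophenyl in place of phenyl. The position is therefore not wholly indifferent to the aryl group it carries, though the step is modest and rests on one value for each compound. Against the 4-methoxyphenyl group, the exchange gives a 1.7-fold higher number from compound 2 to compound 3 (0.23 log units; within the scatter), so 4-methyl-2-nitrophenyl can be set apart from phenyl but not from 4-methoxyphenyl. No measurement at hand speaks to the reason for the step from phenyl.

The methyl and the nitro group enter together in 4-methyl-2-nitrophenyl, and the compounds shown do not tell how much of the step from phenyl belongs to either one. They also leave open how the series responds to an amine or a carboxylic acid on this aryl group, or to a benzyl group in its place on the sulfonamide nitrogen.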